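The source may hold more compounds than are shown below. What is called first, only, known or untested is meant among the compounds shown, and "the series" means these compounds.

Of the compounds shown here, three carrying the same core have been measured in a functional assay on CCRF-SB cells (Homo sapiens) for antiproliferative activity, read by MTT assay, with a stated time of 96 h; a higher number here means a weaker inhibitor, a lower number a stronger inhibitor. Compound 1 `COc1ccc(N2C(=O)NC3(CSC4=C3C(=O)c3ncccc3C4=O)C2=O)cc1` gives 10 nM in this assay, and compound 2 `O=C1C2=C(C(=O)c3ncccc31)C1(CS2)NC(=O)N(c2ccc(Cl)cc2)C1=O` gives 10 nM. Compound 3 `O=C1C2=C(C(=O)c3ncccc31)C1(CS2)NC(=O)N(c2ccc([N+](=O)[O-])cc2)C1=O` gives 2 nM, the lowest of the three numbers; its nearest neighbour is compound 1 at a gap of a 5.0-fold lower number from compound 1 to compound 3 (0.70 log units; beyond the scatter), and compound 2 lies at the same gap, a 5.0-fold lower number from compound 2 to compound 3 (0.70 log units; beyond the scatter). Between compound 1 and compound 2 the difference is no change at the digits printed from compound 1 to compound 2 (within the scatter).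

Compound 4 `CCc1ccc(N2C(=O)NC3(CSC4=C3C(=O)c3ncccc3C4=O)C2=O)cc1` differs from compound 3 in one place: ethyl in place of nitro on an aromatic carbon. The two steps that bear on this are those that put nitro into the same position: from methoxy, a 5.0-fold lower number from compound 1 to compound 3 (0.70 log units; beyond the scatter), and from chloro, a 5.0-fold lower number from compound 2 to compound 3 (0.70 log units; beyond the scatter), both modest and both beyond the scatter. Ethyl, like methoxy and chloro, is not nitro, and there is no direct measurement of ethyl at this position. Removing the nitro is therefore expected to cost most of what it brought, so the number for compound 4 is expected to rise back toward the level of compound 1 and compound 2, an estimated step of a 5.0-fold higher number from compound 3 to compound 4 (0.70 log units; beyond the scatter). Compound 4 is expected to give about 10 nM in this assay, within a range of 4 nM to 30 nM.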

Compound 4, half-maximal inhibitory concentration: 10 nM
Estimate against measurement, compound 4: no gap at the digits printed, and the stated range covers the measured number.
By their numbers in this assay, from the lowest: compound 3; then compounds 1, 2 and 4 (each within the scatter of the next).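

The change from 4-nitrophenyl to 4-ethylphenyl shows, in this assay, that a group of carbon only, with no hydrogen-bond acceptors, lands with the methoxy and chloro compounds rather than with the nitro compound (a 5.0-fold higher number from compound 3 to compound 4 (0.70 log units; beyond the scatter)). Ethyl cannot be told apart from either of those two groups at this place (no change at the digits printed from compound 2 to compound 4 (within the scatter); no change at the digits printed from compound 1 to compound 4 (within the scatter)), so three different groups now give the same reading and nitro alone stands apart among the four compounds, with none of them going against that. The position therefore tolerates quite different groups without any visible shift, and the one step beyond the scatter so far belongs to nitro; nothing shown here gives a measured reason for why nitro differs from the other three groups.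

As far as these compounds go, whether nitro is unique at this place remains open, since a nitrile or a trifluoromethyl group on the same aromatic carbon might sit with compound 3 or with the other three. From the compounds shown here alone, it is equally open whether an amine, a carboxylic acid or a chain longer than ethyl would keep the number of compound 4 or move it in either direction.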